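Chloro in Place of Formyl on a Diaminoquinazoline Core

The source may hold more compounds than are shown below. What is called first, only, known or untested is meant among the compounds shown, and "the series" means these compounds.

Compounds measured so far:
- compound 1 `CCOc1ccc(C=O)cc1-c1cc2nc(N)nc(N)c2cc1C` gives 12 nM in an assay on isolated protein for inhibition of Dihydrofolate reductase (Homo sapiens), read by spectrophotometry, using NADPH, with a stated time of 10 min; on this read-out higher numbers stand for weaker inhibition and lower numbers for stronger inhibition
- compound 2 `CCOc1ccc(-c2cccnc2)cc1-c1ccc2c(N)nc(N)nc2c1` gives 10.1 nM in this assay
- compound 3 `Cc1ccccc1-c1cc2nc(N)nc(N)c2cc1C` gives 95.6 nM in this assay

Among these three numbers compound 1 stands second highest. Its nearest neighbour is compound 2, whose number is slightly lower, a gap that lies within the scatter, so the two cannot be told apart. The furthest is compound 3, whose number is markedly higher, a gap beyond the scatter.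

The unmeasured compound 4 `CCOc1ccc(Cl)cc1-c1cc2nc(N)nc(N)c2cc1C` differs from compound 1 in one place: chloro in place of formyl on an aromatic carbon. Going by the values given here, no measured pair shows this kind of exchange, so there is no step to lean on. The group that leaves carries one hydrogen-bond acceptor; the group that enters carries none, and is smaller. On the evidence of compound 1 and compound 2, which sit close together despite different groups in this region, only a small step is expected, with no direction that can be called beyond the scatter.

Compound 4 is therefore estimated at 15 nM, within the range 5 nM to 45 nM. The step of a 1.3-fold higher number from compound 1 to compound 4 (0.10 log units; within the scatter) is the expected change that this estimate implies.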

Compound 4, inhibition constant: 11.1 nM
Estimate against measurement, compound 4: 1.4-fold (0.13 log units) above; measured number inside the range.
By their numbers in this assay, from the lowest: compounds 2, 4 and 1 (each within the scatter of the next); then compound 3.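

Chloro in place of formyl, on the aromatic carbon para to an ethoxy group, gives a 1.1-fold lower number from compound 1 to compound 4 (0.03 log units; within the scatter) in this assay, a step that leaves the two compounds indistinguishable. At this position, then, the hydrogen-bond acceptor and the double bond of formyl are not needed to hold the number: a single chlorine atom, carrying no hydrogen-bond acceptor, reads the same on the core of compound 1. No measurement shown here accounts for why these two different groups read alike.

As far as these compounds go, it remains open whether this indifference extends to other groups on the same carbon, such as an amine, a carboxylic acid or a longer chain like butoxymethyl. Nor do the compounds shown tell whether a smaller halogen, such as fluoro, or a bare hydrogen there would read the same.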